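The compounds below may be only part of what the source reports. "The series", "measured", "known", "first", "only" and "open" are said of these compounds alone.

Working notes on the series: in a functional assay on Hs-578T cells (Homo sapiens) for inhibition, read by sulforhodamine B assay, with a stated time of 48 h (a lower number here means a stronger inhibitor of growth, a higher number a weaker inhibitor of growth), compound 1 `CN(C)/C=C/C(=O)c1nn(-c2ccccc2)c(-c2ccccc2)c1C#N` gives > 100000 nM, which is a limit of the assay and not a number. Going by the values given here, compound 2 `Cc1nnc(-c2nn(-c3ccccc3)c(-c3ccccc3)c2C#N)c2cn(-c3ccccc3)nc12` gives 1390 nM, the only actual number available so far. Compound 3 `N#Cc1c(-c2nnc(O)c3nn(-c4ccccc4)cc23)nn(-c2ccccc2)c1-c1ccccc1` departs from compound 2 in one place: hydroxy in place of methyl on an aromatic carbon. Among the compounds with values here, no measured step covers this change, so its size is uncertain, but a moderate loss of growth inhibition in this assay is expected. The expected change is a 3.6-fold higher number from compound 2 to compound 3 (0.56 log units; beyond the scatter). Compound 3 is estimated at 5000 nM, with an expected range of 1000 nM to 40000 nM.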

Compound 3, concentration for 50% growth inhibition: 46800 nM
Beside the measured number, compound 3's estimate is 9.4-fold (0.97 log units) below it; measured number above the stated range.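

In this assay, going by these compounds alone, the group on the aromatic carbon next to the ring nitrogen matters: hydroxy in place of methyl gives a 34-fold higher number from compound 2 to compound 3 (1.53 log units; beyond the scatter), the first measured step at this position. Both ends of this step are numbers, so its full size can be read. Compound 1 alone stands at a limit, which is not a number: the limit of > 100000 nM in this assay, at which 1 of the 3 values shown sits.

From the compounds shown here alone, whether the loss is specific to hydroxy or follows any replacement of methyl remains open. Methoxy or an amine at this position would separate these readings, and whether the step carries over to another shared core is also unknown.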